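Propyl pyrazolo series: nitro to methoxy on the aryl ring

This account rests on a few compounds, and the source may have more. Where it says the series, first, only, none or still open, it means among the compounds named here.

Measured so far:
compound 1, `CCCc1n[nH]c2c(=O)n(NC(=O)c3ccncc3)c(-c3cccc(OC)c3)nc12`, 0.07%
compound 2, `O=C(Nn1c(-c2cccc([N+](=O)[O-])c2)nc2c(-c3ccc(Cl)cc3)n[nH]c2c1=O)c1cccnc1`, 15.1%
compound 3, `CCCc1n[nH]c2c(=O)n(NC(=O)c3ccccc3)c(-c3cccc([N+](=O)[O-])c3)nc12`, 18.7%

In a functional assay on HT-29 cells (Homo sapiens) for cytotoxicity, read by sulforhodamine B assay, with a stated time of 2 days, tested at 100 uM (a higher number here means more inhibition at the concentration tested (going by the name of the read-out), a lower number less inhibition), compound 3 gives 18.7%, the highest of the three numbers. Compound 2 gives 15.1%, within the scatter of compound 3, so no order between the two can be claimed. Compound 1 gives 0.07%, beyond the scatter below compound 3; compound 1 carries the methoxy-substituted ring together with a pyridine amide, and shares with compound 3 only the propyl group on the core.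

Compound 4, `CCCc1n[nH]c2c(=O)n(NC(=O)c3ccccc3)c(-c3cccc(OC)c3)nc12`, has not yet been run in this assay. It differs from compound 3 in one place:
methoxy in place of nitro on an aromatic carbon

For the measured compounds named here, no measured pair shows this change alone. Going by the values given here, the only methoxy compound, compound 1, sits near zero in this assay, while both nitro compounds sit higher, but compound 1 also differs in the amide. An estimated step from compound 3 to compound 4 of a number 11.7 percentage points lower from compound 3 to compound 4 (beyond the scatter) is expected, a drop beyond the scatter. Compound 4 is estimated at 7%, with a range of 0% to 20%.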

Compound 4, a percentage reported as inhibition, at one concentration (the size of the read-out at that concentration, not a potency): 6.27%
Compound 4: middle estimate off by 0.7 percentage points, on the high side, and the stated range covers the measured number.
By their numbers in this assay, from the lowest: compounds 1, 4, 2 and 3 (each within the scatter of the next, the first and the last beyond it).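

In this assay, for the compounds shown here, the change from 3-nitrophenyl to 3-methoxyphenyl, read here alone for the first time with the amide and propyl group held fixed, gives a number 12.4 percentage points lower from compound 3 to compound 4 (beyond the scatter) and so shows that this aromatic position affects the number without any change in the amide. The amide ring shows no such separation between the two methoxy compounds: phenyl in place of pyridin-4-yl on the carbonyl carbon gives a number 6.2 percentage points higher from compound 1 to compound 4 (within the scatter) and leaves no difference to interpret. Nothing measured here bears on the reason for the nitro to methoxy step.

On these data alone, whether this step carries over to the chlorophenyl-bearing core of compound 2 remains open. Also open, as far as these compounds go, is how other groups at this position, such as an amine, a hydroxyl or a carboxylic acid, would read at this single concentration.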